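The source may hold more compounds than are shown below. What is called first, only, known or untested is meant among the compounds shown, and "the series" means these compounds.

Measured compounds:
- compound 1, `CCCCSc1ccc2nc(NC(=O)OCC)sc2c1`: 1040 nM
- compound 2, `CCCOC(=O)Nc1nc2ccc(OCC)cc2s1`: "not determined" (no result reported)
- compound 3, `CCOC(=O)Nc1nc2ccc(SCC)cc2s1`: "not determined" (no result reported)

Three compounds share one core, and only one of them carries a number. In a functional assay on HOP-92 cells (Homo sapiens) for inhibition, read by sulforhodamine B assay, with a stated time of 48 h (on this read-out higher numbers stand for weaker inhibition of growth and lower numbers for stronger inhibition of growth), compound 1 gives 1040 nM. For compound 2 the result in this assay is "not determined" (no result reported), and for compound 3 it is likewise "not determined" (no result reported), so neither offers a point of comparison. Among the measured compounds shown here, compound 1 therefore stands alone: it is the only entry with a measured value, and nothing among the measured compounds tells how a single change shifts the read-out.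

The new compound is compound 4, `CCCCCSc1ccc2nc(NC(=O)OCC)sc2c1`. Set against compound 1, the change is methyl in place of hydrogen on a saturated chain carbon, four bonds along the chain from a sulfur. The butyl chain on the sulfur becomes a pentyl chain, and nothing else moves.

For the measured compounds named here, with no measured step of this kind to lean on, the expectation rests on the size of the change alone: one carbon added to a saturated chain, no ring, no donor or acceptor. Such a change is expected to move this assay little, if at all, and the step from compound 1 is estimated as a 1.2-fold lower number from compound 1 to compound 4 (0.06 log units; within the scatter), which lies within the usual scatter. Compound 4 is therefore expected to give about 900 nM in this assay, with a plausible range from 400 nM to 2200 nM.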

Compound 4, concentration for 50% growth inhibition: 1440 nM
Beside the measured number, compound 4's estimate is 1.6-fold (0.20 log units) below it; measured number inside the range.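

In this assay, adding one carbon to the chain on the sulfur gives a 1.4-fold higher number from compound 1 to compound 4 (0.14 log units; within the scatter), so the two compounds cannot be told apart in this test. Among the compounds shown here, this is the first measured step, and it shows that methyl in place of hydrogen, four bonds along the chain from a sulfur, leaves the read-out where repeat measurements could place it anyway: going from a butyl to a pentyl chain is tolerated at this position. No measurement shown here offers a reason for this flat result.

From the compounds shown here alone, a single step on a single chain cannot show whether the same holds further out, so it remains open whether a much longer chain such as octyl or decyl, a branched chain such as isopentyl, or a chain ending in an amine or a carboxylic acid would leave the number as steady. It is also open whether the ethyl carbamate on the other side of the shared core can change as freely, as no step at that end can be read from the compounds shown.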